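Amide for Ester on the Chain of Compound 2

The compounds below may be only part of what the source reports. "The series", "measured", "known", "first", "only" and "open" are said of these compounds alone.

Compound 1, `COc1ccc(-c2cc3c(OC)cc(OC)cc3n(C)c2=O)cc1`: 10000 nM
Compound 2, `CCOC(=O)Cn1c(=O)c(-c2ccc(OC)cc2)cc2c(OC)cc(OC)cc21`: 10000 nM

In a functional assay on HCT-15 cells (Homo sapiens) for cytotoxicity, read by colorimetric assay and MTT assay (on this read-out lower numbers stand for stronger inhibition and higher numbers for weaker inhibition), compound 1 gives 10000 nM and compound 2 gives 10000 nM, so compound 2 stands level with compound 1 at the digits shown. For the measured compounds named here, the single measured step, no change at the digits printed from compound 1 to compound 2 (within the scatter), shows that adding an ethoxycarbonyl group to the chain on the ring nitrogen left the read-out where it was. Compound 3, `CCN(CC)C(=O)Cn1c(=O)c(-c2ccc(OC)cc2)cc2c(OC)cc(OC)cc21`, is a further change at the end of that same chain: diethylamino in place of ethoxy on a carbonyl carbon. Going by the values given here, no measured pair shows this ester-to-amide exchange itself, so the only guide is the earlier step, which was flat. The expected step is therefore none beyond the scatter, no change at the digits printed from compound 2 to compound 3 (within the scatter). Compound 3 is estimated at 10000 nM, with a range from 4000 nM to 25000 nM.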

Compound 3, half-maximal inhibitory concentration: 10000 nM
Estimate against measurement, compound 3: no gap at the digits printed; measured number inside the range.
By their numbers in this assay, from the lowest: compounds 1, 2 and 3 (each within the scatter of the next).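

In this assay the chain on the aromatic nitrogen can now be compared with two different ends, an ester and an amide, and putting diethylamino in place of ethoxy on the carbonyl carbon gives no change at the digits printed from compound 2 to compound 3 (within the scatter) on this read-out. Diethylcarbamoyl in place of hydrogen on the saturated chain carbon likewise gives no change at the digits printed from compound 1 to compound 3 (within the scatter) here, so the amide, like the ester before it, does not move the number away from the simple starting compound. Nothing available here explains this flat result.

Going by these compounds, whether a carboxylic acid or an amine at the end of this chain would shift the value remains open. So does the effect of a longer chain between the aromatic nitrogen and the carbonyl.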